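Propyl to heptyl on the shared core

The source may hold more compounds than are shown below. What is called first, only, known or untested is meant among the compounds shown, and "the series" means these compounds.

Compound 2 `CCCC(c1c[nH]c2ccc(Br)cc12)c1c[nH]c2ccc(Br)cc12` gives 3600 nM in a functional assay on MCF7 cells (Homo sapiens) for inhibition, read by MTT assay, with a stated time of 48 h (on this read-out higher numbers stand for weaker inhibition and lower numbers for stronger inhibition), and compound 1 `Clc1ccc(C(c2c[nH]c3ccc(Br)cc23)c2c[nH]c3ccc(Br)cc23)cc1` gives 3500 nM there, so the two stand level within the scatter. Compound 3 `CCCCCCCC(c1c[nH]c2ccc(Br)cc12)c1c[nH]c2ccc(Br)cc12` turns the propyl of compound 2 into heptyl through butyl in place of hydrogen on a saturated chain carbon, four bonds along the chain from two aromatic carbons on a saturated chain carbon, four bonds along the chain from two aromatic carbons. Within the data shown here, the only measured step (a 1.0-fold higher number from compound 1 to compound 2 (0.01 log units; within the scatter)) stayed within the scatter, but it swapped 4-chlorophenyl for propyl rather than lengthening a chain, so it guides only loosely. No shift beyond the scatter is therefore expected in this assay for this change. The estimated move is a 1.1-fold lower number from compound 2 to compound 3 (0.04 log units; within the scatter) and no more. Compound 3 is expected at 3300 nM (estimated range 1300 nM to 8000 nM).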

Compound 3, half-maximal inhibitory concentration: 5500 nM
Compound 3: middle estimate off by 1.7-fold (0.22 log units), on the low side, and the stated range covers the measured number.
By their numbers in this assay, from the lowest: compounds 1, 2 and 3 (each within the scatter of the next).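

Lengthening the chain from propyl to heptyl gives a 1.5-fold higher number from compound 2 to compound 3 (0.18 log units; within the scatter) in this assay, so this added butyl leaves the value within the scatter. Replacing 4-chlorophenyl with heptyl gives a 1.6-fold higher number from compound 1 to compound 3 (0.20 log units; within the scatter), so these three groups at this position do not separate the compounds beyond the scatter. No supporting measurement is available to explain these small differences. Still open, on these data alone, is whether an amine, a carboxylic acid or a chain longer than heptyl at this position would move the value beyond the scatter.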